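Amino in Place of Chloro: Three Measured, One Awaited

The source may report more compounds than this note shows. Statements on the series, on what has been measured and on what is new or still open speak of the compounds shown alone.

Compound 1 `ClCc1ccccc1Cn1cnc2c(Cl)nc(Cl)nc21`: 3310 nM
Compound 2 `ClCc1cccc(Cn2cnc3c(Cl)nc(Cl)nc32)c1`: 5370 nM
Compound 3 `Nc1nc(Cl)c2ncn(Cc3ccccc3CCl)c2n1`: 20900 nM

In a functional assay on SK-MEL-28 cells (Homo sapiens) for cytotoxicity, read by sulforhodamine B assay, with a stated time of 48 h (a higher number here means a weaker inhibitor of growth, a lower number a stronger inhibitor of growth), compound 1 gives 3310 nM, compound 2 gives 5370 nM, and compound 3 gives 20900 nM. Compound 1 and compound 2 are built from the same atoms joined differently; the difference between their two cores is not broken down here, and their two values lie within the scatter of each other, so no order between them is claimed.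

Compound 3 differs from compound 1 by amino in place of chloro on an aromatic carbon. That single change made a step of a 6.3-fold higher number from compound 1 to compound 3 (0.80 log units; beyond the scatter), a modest move toward weaker growth inhibition.

Compound 4 `Nc1nc(Cl)c2ncn(Cc3cccc(CCl)c3)c2n1` has not yet been measured in this assay. It differs from compound 2 by amino in place of chloro on an aromatic carbon. The place line for this change reads the same word for word as for the change from compound 1 to compound 3, so it is the same change on the other core.

Resting on the step of a 6.3-fold higher number from compound 1 to compound 3 (0.80 log units; beyond the scatter), compound 4 is expected to land at 30000 nM, within 12000 nM to 80000 nM. Within the data shown here, the expected step is a 5.6-fold higher number from compound 2 to compound 4 (0.75 log units; beyond the scatter), with only one earlier example to lean on.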

Compound 4, concentration for total growth inhibition: 19100 nM
Beside the measured number, compound 4's estimate is 1.6-fold (0.20 log units) above it; the measured number falls inside the stated range.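

Amino in place of chloro on an aromatic carbon gave a 3.6-fold higher number from compound 2 to compound 4 (0.55 log units; beyond the scatter) in this assay, so the number moved in the same direction on this core as it had on the core of compound 1. Set side by side, the two steps do not differ by more than repeated measurements of this kind would allow: the same change on two cores in this assay, a 6.3-fold higher number (0.80 log units; beyond the scatter) from compound 1 to compound 3 and a 3.6-fold higher number (0.55 log units; beyond the scatter) from compound 2 to compound 4, 1.8-fold (0.25 log units) apart, within the scatter of two such steps. In these two pairs the change therefore carried over from one core to the other in direction and, within the scatter, in size, but two pairs make no rule for the series and do not show why the number rises.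

The compounds shown leave open whether a methoxy or a dimethylamino group in place of the same chloro would move the number as amino does. They also leave open whether the step would hold on a core other than these two, or in a cell line other than this one.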